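From Isobutyl to a Fluorinated Phenyl Ring

This account rests on a few compounds, and the source may have more. Where it says the series, first, only, none or still open, it means among the compounds named here.

Of the compounds shown here, three sharing one core have been measured in an assay on Sf9 cells for inhibition of serine/threonine-protein kinase 4 (Homo sapiens), read by luminescence and ADP-Glo, with a stated time of 1 h, in the presence of a further agent that is not named here; on this read-out higher numbers stand for weaker inhibition and lower numbers for stronger inhibition. Compound 2 `CC(C)CC1C(=O)N(C)c2cnc(Nc3ccc(S(N)(=O)=O)cc3)nc2N1C` gives 77 nM, the lowest number of the three and thus the strongest inhibitor here. Compound 1 `CN1C(=O)C(CC2CC2)N(C)c2nc(Nc3ccc(S(N)(=O)=O)cc3)ncc21` gives 211 nM, and compound 3 `CN1C(=O)C(c2cccc(C(F)(F)F)c2)N(C)c2nc(Nc3ccc(S(N)(=O)=O)cc3)ncc21` gives 2710 nM. The change a 2.7-fold lower number from compound 1 to compound 2 (0.44 log units; beyond the scatter) is modest, whereas a 13-fold higher number from compound 1 to compound 3 (1.11 log units; beyond the scatter) and a 35-fold higher number from compound 2 to compound 3 (1.55 log units; beyond the scatter) are both large.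

Compound 4 `Cc1ccc(F)cc1C1C(=O)N(C)c2cnc(Nc3ccc(S(N)(=O)=O)cc3)nc2N1C` has not yet been measured. Compared with compound 2 it carries 5-fluoro-2-methylphenyl in place of isobutyl on a saturated ring carbon. The step that bears most directly on this change is a 35-fold higher number from compound 2 to compound 3 (1.55 log units; beyond the scatter), where isobutyl on a saturated ring carbon was likewise replaced by a substituted phenyl; a 13-fold higher number from compound 1 to compound 3 (1.11 log units; beyond the scatter) points the same way. In both cases the substituted phenyl raised the number by a large amount. A large step upward, toward weaker inhibition, is therefore expected in this assay, although the new phenyl carries different substituents, so its exact size is uncertain. Compound 4 is expected to give 1500 nM, with a range from 300 nM to 8000 nM. This estimate means a 19-fold higher number from compound 2 to compound 4 (1.29 log units; beyond the scatter).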

Compound 4, half-maximal inhibitory concentration: 168 nM
The estimate for compound 4 lay 8.9-fold (0.95 log units) above the measured number; measured number below the stated range.
By their numbers in this assay, from the lowest: compound 2; then compounds 4 and 1 (each within the scatter of the next); then compound 3.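

A substituted phenyl ring on this saturated ring carbon does not in itself bring a large penalty: in this assay the change from isobutyl to 5-fluoro-2-methylphenyl gives a 2.2-fold higher number from compound 2 to compound 4 (0.34 log units; beyond the scatter) and no more. What the phenyl ring carries matters greatly, as replacing 3-(trifluoromethyl)phenyl with 5-fluoro-2-methylphenyl gives a 16-fold lower number from compound 3 to compound 4 (1.21 log units; beyond the scatter) in the same assay. Replacing cyclopropylmethyl with 5-fluoro-2-methylphenyl gives a 1.3-fold lower number from compound 1 to compound 4 (0.10 log units; within the scatter) and so leaves the two compounds indistinguishable on this read-out.

The two phenyl rings differ in more than one substituent, so the separate contributions of the fluorine, the methyl and the trifluoromethyl groups remain unresolved, as does the outcome for a phenyl ring bearing an amine or a carboxylic acid. Nothing available here explains why the two phenyl rings give such different numbers.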